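The compounds below may be only part of what the source reports. "The series", "measured", "known", "first", "only" and "open" are said of these compounds alone.

Compounds measured so far:
compound 1 `CN(c1cc2ncc(=O)[nH]c2cc1NC(=S)NC(=O)/C=C/c1ccccc1)C1CCCCC1` — 11000 nM in an ADME assay on Huh-7 cells (Homo sapiens) for cytotoxicity; on this read-out higher numbers stand for weaker inhibition and lower numbers for stronger inhibition
compound 2 `CN(c1cc2ncc(=O)[nH]c2cc1NC(=S)Nc1cccc(C(F)(F)F)c1)C1CCCCC1` — 78400 nM

Among the compounds with values here, of these two numbers in this assay compound 1 holds the lower one, and the only step to compare it with is a 7.1-fold higher number from compound 1 to compound 2 (0.85 log units; beyond the scatter), which replaces the (2-phenylethenyl)carbonyl on the thiourea nitrogen with an aromatic ring. Compound 3 `CN(c1cc2ncc(=O)[nH]c2cc1NC(=S)Nc1cccc2ccccc12)C1CCCCC1` has not yet been measured. It differs from compound 1 by naphthalen-1-yl in place of (2-phenylethenyl)carbonyl on an amide-type nitrogen, so here too the (2-phenylethenyl)carbonyl gives way to an aromatic group, this time one with two six-membered aromatic rings of carbon only and no hydrogen-bond acceptor. The step from compound 1 to compound 2 is the one that bears on this change, and it was modest and beyond the scatter in the direction of a higher number. A step of similar kind is therefore expected, a 4.5-fold higher number from compound 1 to compound 3 (0.66 log units; beyond the scatter), though compound 2 alone is a thin basis. For compound 3 the estimated value in this assay is 50000 nM, with a range from 15000 nM to 160000 nM.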

Compound 3, half-maximal inhibitory concentration: 43600 nM
The estimate for compound 3 lay 1.1-fold (0.06 log units) above the measured number; the range from low to high includes it.
By their numbers in this assay, from the lowest: compound 1; then compounds 3 and 2 (each within the scatter of the next).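

In this assay, a second aromatic group on the amide-type nitrogen, naphthalen-1-yl, also gives a higher number than (2-phenylethenyl)carbonyl (a 4.0-fold higher number from compound 1 to compound 3 (0.60 log units; beyond the scatter)), so compound 1 now stands beyond the scatter from both aromatic replacements. The two aromatic groups are not told apart (a 1.8-fold lower number from compound 2 to compound 3 (0.25 log units; within the scatter)): exchanging 3-(trifluoromethyl)phenyl for naphthalen-1-yl, with its two six-membered aromatic rings of carbon only, leaves the values within the scatter of each other. Nothing measured here accounts for the gap between the (2-phenylethenyl)carbonyl group and the aromatic groups.

The compounds shown do not separate the parts of (2-phenylethenyl)carbonyl, so the carbonyl, the chain double bond and the phenyl ring cannot be weighed individually. From the compounds shown here alone, what a simple acetyl group, a saturated cyclohexyl ring or a phenyl ring carrying an amine or a carboxylic acid would give on this nitrogen also remains open.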